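Chloro for methoxy on the sulfonyl-linked ring

A few compounds are considered here, and "the series" means these few. Any claim that something is new, unique, unknown or untested is made for them only; others in the source may bear on it.

Measured so far in a functional assay (Cavia porcellus) with sulfonylurea receptors; K-ATP channels (Homo sapiens) as the target; a higher number here means a weaker inhibitor, a lower number a stronger inhibitor:
Compound 1, `CC(O)(C(=O)Nc1ccc(S(=O)(=O)c2ccccc2C#N)cc1)C(F)(F)F`, gives 1100 nM.
Compound 2, `COc1ccccc1S(=O)(=O)c1ccc(NC(=O)C(C)(O)C(F)(F)F)cc1`, gives 1600 nM.
Compound 3, `COc1cccc(S(=O)(=O)c2ccc(NC(=O)C(C)(O)C(F)(F)F)cc2)c1`, gives 16000 nM.

Compound 3 stands at the top of these three numbers and is therefore the weakest inhibitor of the set: the steps of a 10-fold higher number from compound 2 to compound 3 (1.00 log units; beyond the scatter) and a 15-fold higher number from compound 1 to compound 3 (1.16 log units; beyond the scatter) both lie beyond the scatter. Between compound 1 and compound 2 no order can be read, since the step of a 1.5-fold higher number from compound 1 to compound 2 (0.16 log units; within the scatter) lies within the scatter.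

Compound 4, `CC(O)(C(=O)Nc1ccc(S(=O)(=O)c2cccc(Cl)c2)cc1)C(F)(F)F`, differs from compound 3 by chloro in place of methoxy on an aromatic carbon. Among the compounds with values here, no measured step exchanges methoxy for chloro, so nothing bears on this change directly. What the measured steps do show is that swapping one small group for another on this ring, as in a 1.5-fold higher number from compound 1 to compound 2 (0.16 log units; within the scatter), changed little, whereas moving the methoxy, as in a 10-fold higher number from compound 2 to compound 3 (1.00 log units; beyond the scatter), changed a great deal. Compound 4 keeps the 3-substituted pattern of compound 3 and only swaps the group, so the expectation for compound 4 is a step of no size beyond the scatter, a 1.2-fold lower number from compound 3 to compound 4 (0.09 log units; within the scatter), with wide uncertainty. Compound 4 is estimated at 13000 nM, between 4000 nM and 40000 nM.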

Compound 4, half-maximal inhibitory concentration: 10000 nM
Compound 4: the middle estimate sits 1.3-fold (0.11 log units) above what was measured, within the range that was stated.
By their numbers in this assay, from the lowest: compounds 1 and 2 (each within the scatter of the next); then compounds 4 and 3 (each within the scatter of the next).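

Chloro in place of methoxy on the 3-substituted ring gives little change in this assay (a 1.6-fold lower number from compound 3 to compound 4 (0.20 log units; within the scatter)), so this assay does not separate the two groups at this place, even though methoxy has 2 heavy atoms and 1 hydrogen-bond acceptor while chloro has 1 heavy atom and 0 hydrogen-bond acceptors. The weak standing of compound 3 is therefore not unique to methoxy: the 3-chlorophenyl compound also stays well apart from the 2-methoxyphenyl compound (a 6.3-fold higher number from compound 2 to compound 4 (0.80 log units; beyond the scatter)) and the 2-cyanophenyl compound (a 9.1-fold higher number from compound 1 to compound 4 (0.96 log units; beyond the scatter)), and among these four compounds none goes against this split. No measurement bearing on the reason for these numbers is available.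

The compounds shown leave open whether 2-chlorophenyl would give a number close to those of the 2-methoxyphenyl and 2-cyanophenyl compounds, which would show whether the place of the group, and not the group itself, carries this gap. Going by these compounds, it also remains open whether an amine, a carboxylic acid or a longer chain on the same ring carbon would match chloro and methoxy.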